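Triazole ethers on a shared core: dropping the methoxy

A few compounds are considered here, and "the series" means these few. Any claim that something is new, unique, unknown or untested is made for them only; others in the source may bear on it.

Compounds assessed in an ADME assay on HEK293 cells (Homo sapiens) for inhibition, read by MTT assay, with a stated time of 48 h, tested at 25 uM; on this read-out lower numbers stand for less inhibition and higher numbers for more inhibition at the one concentration tested (going by the name of the read-out):
compound 1 `Brc1ccc(-n2cc(COc3ccc4c(c3)CCC4)nn2)cc1` — "not determined" (no result reported)
compound 2 `O=[N+]([O-])c1cccc(-n2cc(COc3ccc4c(c3)CCC4)nn2)c1` — "not determined" (no result reported)
compound 3 `COc1cccc(-n2cc(COc3ccc4c(c3)CCC4)nn2)c1` — 25.8%

Among the compounds with values here, compound 3 is the only member of the series with a number; compounds 1 and 2 carry no reported result, so no step between measured compounds can be drawn and compound 3 stands alone as the sole point of reference. Compound 4 `c1ccc(-n2cc(COc3ccc4c(c3)CCC4)nn2)cc1` is the next entry to be measured in this assay. Its difference from compound 3 is hydrogen in place of methoxy on an aromatic carbon; cut one bond further out, it reads 3-methoxyphenyl to phenyl. Within the data shown here, with no measured step to lean on, the expectation is a step of a number 3.8 percentage points lower from compound 3 to compound 4 (within the scatter), small and not beyond the scatter. Compound 4 is therefore estimated at 22%, with a range from 8% to 40%.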

Compound 4, a percentage reported as inhibition, at one concentration (the size of the read-out at that concentration, not a potency): 23.4%
Estimate against measurement, compound 4: 1.4 percentage points below; the range from low to high includes it.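

In this assay, within the data shown here, hydrogen in place of methoxy gives a number 2.4 percentage points lower from compound 3 to compound 4 (within the scatter) and so the first readable step. On an aromatic carbon meta to a large group, compound 3 and compound 4 cannot be told apart, and the methoxy is not required for a measurable reading at this place. No measured evidence bears on the reason for this result.

From the compounds shown here alone, whether an amine or a carboxylic acid at the same place would separate from compound 4 remains open. Compound 1 and compound 2 have no numbers, so their steps cannot be read.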